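This account rests on a few compounds, and the source may have more. Where it says the series, first, only, none or still open, it means among the compounds named here.

Of the compounds shown here, three sharing one core have been tested in a functional assay on A549 cells (Homo sapiens) for antiproliferative activity, read by MTT assay (a higher number here means a weaker inhibitor, a lower number a stronger inhibitor), and differ only in the group on a carbon with a double bond to nitrogen. Compound 1 `Cn1c(=O)c(=O)n(C2CCCC2)c2nc(N/N=C/c3ccco3)ncc21` carries furan-2-yl and gives > 100000 nM as its reading, a limit of the assay and not a number. Compound 2 `Cn1c(=O)c(=O)n(C2CCCC2)c2nc(N/N=C/c3cccc(O)c3)ncc21` carries 3-hydroxyphenyl and gives > 100000 nM as its reading, again only a limit. Among the measured compounds shown here, compound 3 `Cn1c(=O)c(=O)n(C2CCCC2)c2nc(N/N=C/c3ccc(F)cc3Br)ncc21` carries 2-bromo-4-fluorophenyl and gives 6590 nM as the only true number here: the data show an at least 15-fold lower number from compound 1 to compound 3 (1.18 log units; beyond the scatter) and an at least 15-fold lower number from compound 2 to compound 3 (1.18 log units; beyond the scatter) as large steps.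

For the measured compounds named here, compound 4 `Cn1c(=O)c(=O)n(C2CCCC2)c2nc(N/N=C/c3ccccc3Cl)ncc21` changes only that group, as 2-chlorophenyl in place of 2-bromo-4-fluorophenyl on a carbon with a double bond to nitrogen shows, with 2-chlorophenyl in place of 2-bromo-4-fluorophenyl. Going by the values given here, those two steps bear on this change only loosely: no measured step compares two halogen-bearing phenyl groups. The closest reference is compound 3 at 6590 nM and compound 4 keeps such a group. A slightly higher number is expected, with a 1.5-fold higher number from compound 3 to compound 4 (0.18 log units; within the scatter) as the estimated step, possibly no larger than the scatter. Compound 4 is estimated at 10000 nM with an expected range of 2500 nM to 50000 nM in this measurement.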

Compound 4, half-maximal inhibitory concentration: 9860 nM
Estimate against measurement, compound 4: 1.0-fold (0.01 log units) above, within the range that was stated.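

In this assay there is a 1.5-fold higher number from compound 3 to compound 4 (0.17 log units; within the scatter), so 2-chlorophenyl and 2-bromo-4-fluorophenyl cannot be told apart here, and a readable value at this position no longer rests on compound 3 alone. Set against the two groups without a halogen, the data show an at least 10-fold lower number from compound 2 to compound 4 (1.00 log units; beyond the scatter) and an at least 10-fold lower number from compound 1 to compound 4 (1.00 log units; beyond the scatter), so both halogen-bearing phenyl groups read clearly stronger than furan-2-yl and 3-hydroxyphenyl. These two sizes are only minimums, since each starts from a limit of the assay and not a number: the limit of > 100000 nM in this assay, at which 2 of the 4 values shown sit.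

The compounds shown leave open whether the halogen itself is what counts, since a plain phenyl group is not among them. Going by these compounds, whether a phenyl group carrying a methyl, an amine or a carboxylic acid would read like compound 4 also stays open.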